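Ethylcarbamoyl for Carboxymethyl: Expected Tolerance of Compound 4

The source may hold more compounds than are shown below. What is called first, only, known or untested is meant among the compounds shown, and "the series" means these compounds.

Measured compounds in a functional assay on HEL cells (Homo sapiens); a higher number here means that more compound is tolerated, a lower number that less compound is tolerated:
compound 1 `Cc1cn([C@@H]2O[C@H](CO[Si](C)(C)C(C)(C)C)[C@@]3(OS(=O)(=O)C=C3NCC(=O)O)[C@H]2O[Si](C)(C)C(C)(C)C)c(=O)n(C)c1=O` gives 136000 nM
compound 2 `COC(=O)NC1=CS(=O)(=O)O[C@@]12[C@@H](CO[Si](C)(C)C(C)(C)C)O[C@@H](n1cc(C)c(=O)n(C)c1=O)[C@@H]2O[Si](C)(C)C(C)(C)C` gives > 200000 nM
compound 3 `Cc1cn([C@@H]2O[C@H](CO[Si](C)(C)C(C)(C)C)[C@@]3(OS(=O)(=O)C=C3NCC(=O)OCc3ccccc3)[C@H]2O[Si](C)(C)C(C)(C)C)c(=O)n(C)c1=O` gives > 200000 nM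

For the measured compounds named here, compound 1 stands as the only compound with a numerical reading in this assay. The reading for compound 2 is a limit of the assay, not a number. The reading for compound 3 is likewise a limit. Both sit at the limit of > 200000 nM in this assay, at which 2 of the 3 values shown sit.

Compound 4 `CCNC(=O)NC1=CS(=O)(=O)O[C@@]12[C@@H](CO[Si](C)(C)C(C)(C)C)O[C@@H](n1cc(C)c(=O)n(C)c1=O)[C@@H]2O[Si](C)(C)C(C)(C)C` differs from compound 1 in one place: ethylcarbamoyl in place of carboxymethyl on an amine nitrogen. The measured steps that touch the same amine nitrogen are an at least 1.4-fold higher number from compound 1 to compound 2 (0.16 log units; that floor lies within the scatter) and an at least 1.4-fold higher number from compound 1 to compound 3 (0.16 log units; that floor lies within the scatter); both exchange the carboxymethyl group or its acid hydrogen for a neutral ester-type group and both move to the limit. The step that the two limits leave unreadable from compound 2 to compound 3 cannot be sized from two limits. The ethylcarbamoyl group of compound 4 removes the acid in the same way, so the expected move is a 1.5-fold higher number from compound 1 to compound 4 (0.17 log units; within the scatter), upward or flat within the scatter, and most probably again a reading at the limit. Compound 4 is therefore estimated at 200000 nM, with a range from 110000 nM to 400000 nM.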

Compound 4, half-maximal cytotoxic concentration: 10000 nM
For compound 4 the middle estimate is 20-fold (1.30 log units) above the measured one, outside the stated range (below it).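

In this assay, for the compounds shown here, the amine nitrogen on the double-bonded ring carbon proves able to push the reading down, which the earlier compounds never showed: ethylcarbamoyl in place of carboxymethyl gives a 14-fold lower number from compound 1 to compound 4 (1.13 log units; beyond the scatter). Losing the carboxymethyl group is therefore not what decides the outcome, since compound 2 and compound 4 both lack it and still part widely, with ethylamino in place of methoxy on a carbonyl carbon giving an at least 20-fold lower number from compound 2 to compound 4 (1.30 log units; beyond the scatter), while ethylcarbamoyl in place of (benzyloxycarbonyl)methyl gives an at least 20-fold lower number from compound 3 to compound 4 (1.30 log units; beyond the scatter). Compound 2 and compound 3 each carry a limit of the assay and not a number: the limit of > 200000 nM in this assay, at which 2 of the 4 values shown sit.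

The compounds shown do not tell whether the drop belongs to the ethyl chain or to the carbamoyl unit as a whole, and nothing here says why the change lowers the tolerated concentration. A methyl or a longer butyl chain on the carbamoyl nitrogen, or a simple acetyl group on the same amine nitrogen, would be the neighbours that could separate these two readings.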